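Compound 2 to compound 3: methyl for methylamino

The compounds below may be only part of what the source reports. "The series", "measured", "known", "first", "only" and "open" are said of these compounds alone.

Compound 2 `CNc1ncnc2c1c(I)cn2[C@@H]1O[C@H](CO)[C@@H](O)[C@H]1O` gives > 100000 nM in a functional assay on K562 cells (Homo sapiens), read by MTT assay, with a stated time of 72 h (on this read-out lower numbers stand for stronger inhibition and higher numbers for weaker inhibition), and this value is a limit of the assay, not a number. Compound 1 `C#Cc1cn([C@@H]2O[C@H](CO)[C@@H](O)[C@H]2O)c2ncnc(C)c12` also bears a methyl on the core and gives 6920 nM as a true number in this assay under the same conditions. Compound 3 `Cc1ncnc2c1c(I)cn2[C@@H]1O[C@H](CO)[C@@H](O)[C@H]1O` differs from compound 2 by one change, methyl in place of methylamino on an aromatic carbon with methyl in place of methylamino on an aromatic carbon. Within the data shown here, with compound 1 at 6920 nM as the only guide to a methyl-bearing compound, a large step towards stronger inhibition is expected in this assay and is estimated as an at least 16-fold lower number from compound 2 to compound 3 (1.22 log units; beyond the scatter) beyond the scatter. Compound 3 is estimated at 6000 nM with an expected range of 700 nM to 50000 nM in this read-out.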

Compound 3, half-maximal inhibitory concentration: 17800 nM
For compound 3 the middle estimate is 3.0-fold (0.47 log units) below the measured one; the range from low to high includes it.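

In this assay, methyl in place of methylamino on an aromatic carbon gives an at least 5.6-fold lower number from compound 2 to compound 3 (0.74 log units; beyond the scatter), so this position can move the read-out from the top of the assay's range to a true number while iodo stays on the shared core. Compound 2 gives only a limit, not a number, which leaves the full size of this step unknown: the limit of > 100000 nM in this assay, at which 1 of the 3 values shown sits. With methyl held constant, iodo in place of ethynyl gives a 2.6-fold higher number from compound 1 to compound 3 (0.41 log units; beyond the scatter), showing that the second substituent also matters, though this step is modest.

The compounds shown do not separate loss of methylamino from gain of methyl, and a primary amine or an ethyl group at this position would test that. From the compounds shown here alone, whether a chloro or bromo group would behave like iodo also remains open.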